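Two indole carboxamides and a third awaiting its half-life

The source may hold more compounds than are shown below. What is called first, only, known or untested is meant among the compounds shown, and "the series" means these compounds.

Compound 1: `COc1ccc2[nH]c(C(=O)N3CC(=O)N(Cc4ccccc4)[C@@H](COc4ccccc4)C3)cc2c1` gives 0.65 h in an ADME assay on microsomes from liver (Homo sapiens) for metabolic stability, with a stated time of 30 min, tested at 1 uM; a lower number here means that the compound disappears faster, a higher number that the compound lasts longer.
Compound 2: `COc1ccc2[nH]c(C(=O)N3CC(=O)N(Cc4ccccc4)[C@@H](N4CCC(Cc5ccccc5)CC4)C3)cc2c1` gives 0.597 h in this assay.

Compound 1 shows the higher of the two numbers, but compound 2 sits within the scatter of it, so the two compounds are read as equal in this assay. For the measured compounds named here, no step between measured compounds that differ in a single place is available here.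

Compound 3, `COc1ccc2[nH]c(C(=O)N3CC(=O)N(Cc4ccccc4)[C@@H](N4CCc5ccccc54)C3)cc2c1`, differs from compound 1 by 2,3-dihydro-1H-indol-1-yl in place of phenoxymethyl on a saturated ring carbon. Compound 2, which gives 0.597 h, already carries a nitrogen-linked ring at that same saturated ring carbon and does not separate from compound 1 in this assay, so nothing seen so far points to a shift beyond the scatter for compound 3.

Compound 3 is therefore expected to land near the two measured values, and the step of a 1.2-fold lower number from compound 1 to compound 3 (0.07 log units; within the scatter) is estimated to fall within the scatter. The half-life of compound 3 is estimated at 0.55 h, with a range from 0.3 h to 1 h.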

Compound 3, half-life: 0.25 h
The estimate for compound 3 lay 2.2-fold (0.34 log units) above the measured number; measured number outside the range, below it.
By their numbers in this assay, from the lowest: compound 3; then compounds 2 and 1 (each within the scatter of the next).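

In this assay, for the compounds shown here, the saturated ring carbon proves sensitive to the group it carries: 2,3-dihydro-1H-indol-1-yl in place of phenoxymethyl gives a 2.6-fold lower number from compound 1 to compound 3 (0.41 log units; beyond the scatter), the only step at this position that can be read so far. A nitrogen-linked ring at this carbon does not by itself set the half-life, since compound 2 gives 0.597 h while compound 3 gives 0.25 h. Nothing shown here accounts for the lower number.

From the compounds shown here alone, it remains open which part of 2,3-dihydro-1H-indol-1-yl goes with the lower number, the nitrogen link or the ring system that it carries. Going by these compounds, it is equally open whether a small open-chain amine such as dimethylamino, or a carboxylic acid, at this carbon would stay near compound 1 or fall toward compound 3.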